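The compounds below may be only part of what the source reports. "The series", "measured", "known", "first", "only" and "open" are said of these compounds alone.

Of the compounds shown here, three have so far been measured in an assay for binding affinity to 17-beta-hydroxysteroid dehydrogenase type 2 (Homo sapiens), with a stated time of 20 min, tested at 1 uM; on this read-out higher numbers stand for more inhibition at the one concentration tested (going by the name of the read-out) and lower numbers for less inhibition. Compound 1, with the structure `Oc1ccc2cc(-c3ccccc3O)ccc2c1`, returns only a limit of the assay in this assay, < 10%. Compound 2, with the structure `Oc1cccc(-c2ccc3ccccc3c2)c1`, gives 12% in this assay. Compound 3, with the structure `COc1ccc(-c2ccc3c(O)cccc3c2)cc1`, gives 20% in this assay; its number and that of compound 2 lie within the scatter of each other, so no order between them can be read. The remaining value, that of compound 1, is a limit rather than a number (the limit of < 10% in this assay, at which 1 of the 3 values shown sits).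

Compound 4, with the structure `Oc1cccc2cc(-c3ccc(F)cc3)ccc12`, has not yet been measured in this assay. It differs from compound 3 in a single place: fluoro in place of methoxy on an aromatic carbon. Going by the values given here, no step between two measured compounds matches this change, so the size of its effect has to be guessed. Fluoro in place of methoxy is a small change, and a step that stays within the scatter is expected; the step from compound 3 to compound 4 in this assay is estimated at a number 5 percentage points lower from compound 3 to compound 4 (within the scatter). Compound 4 is therefore expected to give about 15% in this assay, between 5% and 30%.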

Compound 4, a percentage reported as inhibition, at one concentration (the size of the read-out at that concentration, not a potency): < 10%
Compound 4: a limit, no number; the forecaster's own chance of this, stated with the estimate: 30%; middle value at least 5 percentage points from the limit.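

Putting fluoro in place of methoxy on this aromatic carbon, para to a large group, gives a number at least 10 percentage points lower from compound 3 to compound 4 (that floor lies within the scatter) in this assay. Going by these compounds alone, this is the first direct comparison at this position, but the smallest step the values allow still lies within the usual scatter, so they do not establish that the change matters. The full size of the step cannot be read because the result for compound 4 is a limit of the assay and not a number: the limit of < 10% in this assay, at which 2 of the 4 values shown sit.

The compounds shown leave open what an amine, a carboxylic acid or a longer chain on this same carbon would give in this assay. Within the data shown here, with only one pair to compare, they also cannot show whether fluoro in place of methoxy would have a similar effect at another position or on a different core.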